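Cyclopropyl for furan-2-yl in the urea series

The source may hold more compounds than are shown below. What is called first, only, known or untested is meant among the compounds shown, and "the series" means these compounds.

Measured so far in a functional assay on HCT-116 cells (Homo sapiens) for cytotoxicity, read by MTT assay, with a stated time of 48 h, in the presence of a further agent that is not named here; a higher number here means that more compound is needed for the effect, a lower number that less compound is needed:
compound 1 `CC(C)c1cc(NNC(=O)Nc2cc(Cl)nc(Cl)c2)nc2c1c(C(F)(F)F)nn2C` gives 27200 nM;
compound 2 `Cc1nn(C)c2nc(NNC(=O)Nc3cc(Cl)nc(Cl)c3)cc(-c3ccc(F)cc3)c12` gives 25200 nM;
compound 3 `Cc1nn(C)c2nc(NNC(=O)Nc3cc(Cl)nc(Cl)c3)cc(-c3ccco3)c12` gives 69200 nM.

Compound 3 stands highest of the three numbers, beyond the scatter from both compound 1 and compound 2. Going by the values given here, the one single-place step among the measured compounds leads to it: a 2.7-fold higher number from compound 2 to compound 3 (0.44 log units; beyond the scatter). Compound 1 differs from compound 3 in more than one place, so its value only shows that a compound without an aromatic substituent at that position sits well below compound 3.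

Compound 4 `Cc1nn(C)c2nc(NNC(=O)Nc3cc(Cl)nc(Cl)c3)cc(C3CC3)c12` carries the change (cyclopropyl in place of furan-2-yl on an aromatic carbon). Among the compounds with values here, no measured step covers a cyclopropyl group, so the expectation rests on the step from compound 2 to compound 3, which moved the number up in this assay on exchange of the aromatic substituent, and on the low number of compound 1. Removing the furan-2-yl is therefore expected to bring the number back down, with a modest step of a 2.0-fold lower number from compound 3 to compound 4 (0.30 log units; within the scatter), though the direction is uncertain. Compound 4 is estimated at 35000 nM in this assay, within 15000 nM to 85000 nM.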

Compound 4, half-maximal effective concentration: 67700 nM
Compound 4: the middle estimate sits 1.9-fold (0.29 log units) below what was measured; the range from low to high includes it.
By their numbers in this assay, from the lowest: compounds 2 and 1 (each within the scatter of the next); then compounds 4 and 3 (each within the scatter of the next).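

In this assay, the exchange on this aromatic carbon gives a 1.0-fold lower number from compound 3 to compound 4 (0.01 log units; within the scatter), so furan-2-yl and cyclopropyl cannot be told apart here, although one is a five-membered aromatic ring with a hetero atom and the other a three-membered non-aromatic ring of carbon only. The 4-fluorophenyl group now stands apart from both, with a 2.7-fold higher number from compound 2 to compound 4 (0.43 log units; beyond the scatter) alongside a 2.7-fold higher number from compound 2 to compound 3 (0.44 log units; beyond the scatter), so among these three groups on the shared core only 4-fluorophenyl gives the lower number. No measurement at hand accounts for this difference. From the compounds shown here alone, whether the lower number of compound 2 depends on the fluorine or on the phenyl ring itself remains open, and an unsubstituted phenyl would separate the two. Also open, going by these compounds, is how a basic amine such as morpholine or a carboxylic acid on this carbon would read in this assay.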